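The source may report more compounds than this note shows. Statements on the series, on what has been measured and on what is new or still open speak of the compounds shown alone.

Of the compounds shown here, three of one series have been measured in a functional assay on CHO-K1 cells for antagonist activity at prostaglandin E2 receptor EP3 subtype (Homo sapiens), read by TR-FRET and cAMP accumulation, with a stated time of 30 min; on this read-out higher numbers stand for weaker inhibition and lower numbers for stronger inhibition. Compound 1 `O=C(NC/C=C1\CCCc2cnn(Cc3ccc(Cl)cc3Cl)c21)NS(=O)(=O)c1cc(Cl)c(Cl)s1` gives 11 nM, compound 2 `COc1ccccc1S(=O)(=O)NC(=O)NC/C=C1\CCCc2cnn(Cc3ccc(Cl)cc3Cl)c21` gives 114 nM, and compound 3 `O=C(NC/C=C1\CCCc2cnn(Cc3ccc(Cl)cc3Cl)c21)NS(=O)(=O)c1ccc(Cl)cc1` gives 12 nM. Compound 3 sits second highest of the three numbers; its nearest neighbour is compound 1, within the scatter, while compound 2 lies furthest from it, as the step of a 9.5-fold lower number from compound 2 to compound 3 (0.98 log units; beyond the scatter) shows.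

Compound 4 `COc1ccc(Cl)cc1S(=O)(=O)NC(=O)NC/C=C1\CCCc2cnn(Cc3ccc(Cl)cc3Cl)c21` has not yet been measured. It differs from compound 3 in one place: 5-chloro-2-methoxyphenyl in place of 4-chlorophenyl on a sulfonyl sulfur.

Among the measured compounds shown here, two measured steps bear on this change. The step of a 9.5-fold lower number from compound 2 to compound 3 (0.98 log units; beyond the scatter) shows that a 2-methoxyphenyl on the sulfonyl sulfur gave a markedly higher number than a 4-chlorophenyl, and the step of a 10-fold higher number from compound 1 to compound 2 (1.02 log units; beyond the scatter) points the same way against the 4,5-dichlorothiophen-2-yl group. Compound 4 carries a methoxy group on its aryl like compound 2 does, but also a chlorine, as compound 3 does, so the number is expected to rise from compound 3, though not fully to the value of compound 2. Compound 4 is therefore expected to give a step of a 3.8-fold higher number from compound 3 to compound 4 (0.57 log units; beyond the scatter), moving toward weaker inhibition. Compound 4 is estimated at 45 nM, with a range from 15 nM to 140 nM.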

Compound 4, half-maximal inhibitory concentration: 8 nM
Compound 4: the middle estimate sits 5.6-fold (0.75 log units) above what was measured; the measured number lies below the stated range.
By their numbers in this assay, from the lowest: compounds 4, 1 and 3 (each within the scatter of the next); then compound 2.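

In this assay, chloro in place of hydrogen on an aromatic carbon gives a 14-fold lower number from compound 2 to compound 4 (1.15 log units; beyond the scatter) and so separates two compounds that both carry a methoxy group on the aryl; the high number of compound 2 therefore does not follow from the methoxy group alone, since the 5-chloro-2-methoxyphenyl group of compound 4 keeps that methoxy. The other two steps, a 1.5-fold lower number from compound 3 to compound 4 (0.18 log units; within the scatter) and a 1.4-fold lower number from compound 1 to compound 4 (0.14 log units; within the scatter), show that 5-chloro-2-methoxyphenyl on a sulfonyl sulfur cannot be told apart on this read-out from either 4-chlorophenyl or 4,5-dichlorothiophen-2-yl, which adds a third group to the set of sulfonyl substituents that lie within the scatter of one another. No measurement shown here speaks to how the added chloro produces this large step.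

The compounds shown leave open whether the chloro of compound 4 could be exchanged for fluoro, bromo, methyl or a nitrile while the number stays this low. They also leave open whether the methoxy group matters at all once the chloro is present, which a hydroxyl, an ethoxy group or a plain hydrogen in its place would test.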